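Propyl for ethyl on a shared core, revisited

The compounds below may be only part of what the source reports. "The series", "measured", "known", "first", "only" and "open" are said of these compounds alone.

Of the compounds shown here, three of one family have been tested. Compound 1 `CCN1CC[C@@]2(OC)OC(N)=C(C#N)[C@@H](c3ccc(Br)cc3)[C@@H]2C1` is a starting point; in a functional assay on trachea (Cavia porcellus) (a lower number here means a stronger inhibitor, a higher number a weaker inhibitor), compound 1 gives 13200 nM. Compound 2 `CCCN1CC[C@@]2(OC)OC(N)=C(C#N)[C@@H](c3ccc(Br)cc3)[C@@H]2C1` differs from it by a single change, (methyl in place of hydrogen on a saturated chain carbon, two bonds along the chain from an amine nitrogen in a ring), which gave a 1.5-fold higher number from compound 1 to compound 2 (0.17 log units; within the scatter). Compound 3 `CCN1CC[C@@]2(OC)OC(N)=C(C#N)[C@@H](c3ccc(OC)cc3)[C@@H]2C1` carries another change, (methoxy in place of bromo on an aromatic carbon), and in this assay compound 3 gives 25500 nM. Compound 2 in this assay gives 19400 nM; the three numbers lie close together.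

Compound 4 `CCCN1CC[C@@]2(OC)OC(N)=C(C#N)[C@@H](c3ccc(OC)cc3)[C@@H]2C1` has not been measured. It comes from compound 3 through (methyl in place of hydrogen on a saturated chain carbon, two bonds along the chain from an amine nitrogen in a ring), the same change that turned compound 1 into compound 2, at the same place on the chain. The two cores differ only by the change from compound 1 to compound 3 described above. Since the change on compound 1 moved the number only a little, compound 4 is expected to follow compound 3 by a similar small step, about a 1.4-fold higher number from compound 3 to compound 4 (0.14 log units; within the scatter), because compound 2 showed a 1.5-fold higher number from compound 1 to compound 2 (0.17 log units; within the scatter). The estimate for compound 4 in this assay is 35000 nM, with a range from 15000 nM to 80000 nM.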

Compound 4, half-maximal inhibitory concentration: 21300 nM
Beside the measured number, compound 4's estimate is 1.6-fold (0.22 log units) above it; low and high end bracket the measured number.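

The methyl that turns ethyl into propyl gave a 1.2-fold lower number from compound 3 to compound 4 (0.08 log units; within the scatter) in this assay, and this step cannot be told apart from the one seen earlier on the other core: the same change on two cores in this assay, a 1.5-fold higher number (0.17 log units; within the scatter) from compound 1 to compound 2 and a 1.2-fold lower number (0.08 log units; within the scatter) from compound 3 to compound 4, 1.8-fold (0.25 log units) apart, within the scatter of two such steps. Methoxy in place of bromo, read on the propyl pair, gave a 1.1-fold higher number from compound 2 to compound 4 (0.04 log units; within the scatter), and this step also agrees with its earlier reading: the same change on two cores in this assay, a 1.9-fold higher number (0.29 log units; within the scatter) from compound 1 to compound 3 and a 1.1-fold higher number (0.04 log units; within the scatter) from compound 2 to compound 4, 1.8-fold (0.25 log units) apart, within the scatter of two such steps. Among the compounds shown here, both changes therefore carry over between these two cores with no detectable difference, but every step lies within the scatter, so this does not show the direction of either change, nor does a test on only two cores show that the changes would behave alike on others.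

The compounds shown carry only ethyl or propyl on the amine nitrogen in the ring, and only bromo or methoxy on the aromatic carbon. On these data alone, whether a longer chain at the first place, or an amine or a carboxylic acid at the second, would move the number beyond the scatter remains open.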